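Paired aryl sulfonates: nitro to dimethylamino in two cores

A few compounds are considered here, and "the series" means these few. Any claim that something is new, unique, unknown or untested is made for them only; others in the source may bear on it.

The study compares three measured compounds and one yet to be measured. Compound 1, `N#Cc1cccc(S(=O)(=O)Oc2ccc(-c3cncn3C3CCN(C(=O)c4ccc([N+](=O)[O-])cc4)CC3)cc2)c1`, gives 45 nM in an assay on HEK293 cells for antagonist activity at P2X purinoceptor 7 (Homo sapiens), read by fluorescence, with a stated time of 2 h; on this read-out lower numbers stand for stronger inhibition and higher numbers for weaker inhibition. Compound 2, `CN(C)c1ccc(C(=O)N2CCC(n3cncc3-c3ccc(OS(=O)(=O)c4cccc(C#N)c4)cc3)CC2)cc1`, carries the change dimethylamino in place of nitro on an aromatic carbon and gives 32 nM in this assay; the step of a 1.4-fold lower number from compound 1 to compound 2 (0.15 log units; within the scatter) is small. Compound 3, `CNC(=O)c1cccc(S(=O)(=O)Oc2ccc(-c3cncn3C3CCN(C(=O)c4ccc([N+](=O)[O-])cc4)CC3)cc2)c1`, differs from compound 1 by methylcarbamoyl in place of cyano on an aromatic carbon; in this assay compound 3 gives 62 nM, a step of a 1.4-fold higher number from compound 1 to compound 3 (0.14 log units; within the scatter). All three values lie within the scatter of one another, so no order among them can be stated.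

Compound 4, `CNC(=O)c1cccc(S(=O)(=O)Oc2ccc(-c3cncn3C3CCN(C(=O)c4ccc(N(C)C)cc4)CC3)cc2)c1`, is the unmeasured member. It differs from compound 3 by dimethylamino in place of nitro on an aromatic carbon. This is the same change that separates compound 2 from compound 1, now made on the core of compound 3 rather than on the core of compound 1; the two cores differ by methylcarbamoyl in place of cyano on an aromatic carbon. The change has been seen once, as a 1.4-fold lower number from compound 1 to compound 2 (0.15 log units; within the scatter).

Because a 1.4-fold lower number from compound 1 to compound 2 (0.15 log units; within the scatter) was small and the cores of compound 1 and compound 3 sit within the scatter of each other, the account expects compound 4 to show a similarly small step, a 1.4-fold lower number from compound 3 to compound 4 (0.14 log units; within the scatter), in this assay. Compound 4 is therefore estimated at 45 nM in this assay, with a range from 20 nM to 100 nM reflecting that the expectation rests on a single prior step of this change.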

Compound 4, half-maximal inhibitory concentration: 25 nM
Estimate against measurement, compound 4: 1.8-fold (0.26 log units) above; the range from low to high includes it.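

In this assay, dimethylamino in place of nitro on the core of compound 3 gives a 2.5-fold lower number from compound 3 to compound 4 (0.39 log units; beyond the scatter), and this step agrees with the one seen earlier on the core of compound 1: the same change on two cores in this assay, a 1.4-fold lower number (0.15 log units; within the scatter) from compound 1 to compound 2 and a 2.5-fold lower number (0.39 log units; beyond the scatter) from compound 3 to compound 4, 1.8-fold (0.25 log units) apart, within the scatter of two such steps. Read the other way around the same four compounds, methylcarbamoyl in place of cyano on the dimethylamino-bearing core gives a 1.3-fold lower number from compound 2 to compound 4 (0.11 log units; within the scatter), and this step likewise agrees with its counterpart on the nitro-bearing core: the same change on two cores in this assay, a 1.4-fold higher number (0.14 log units; within the scatter) from compound 1 to compound 3 and a 1.3-fold lower number (0.11 log units; within the scatter) from compound 2 to compound 4, 1.8-fold (0.25 log units) apart, within the scatter of two such steps. Among the compounds shown here, these four compounds therefore show that the nitro to dimethylamino change carries from one core to the other without a measurable difference in its step, but they do not fix the size of that step, since only one of the two steps lies beyond the scatter, and they offer no reason for it and speak for this one pair of cores alone.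

The compounds shown leave open whether an unsubstituted amino group or a carboxylic acid in place of dimethylamino would follow the same course on these two cores. They also leave open whether a longer chain in place of the methyl of methylcarbamoyl, or a sulfonamide in place of the sulfonate, would alter how the change carries over.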